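A smaller ring and the expected effect on cytotoxicity

The source may report more compounds than this note shows. Statements on the series, on what has been measured and on what is new or still open speak of the compounds shown alone.

Compound 1 (`Cc1noc(C)c1-c1cc(-c2c(C3CC3)n[nH]c2C)c2[nH]c(C3CC3)nc2c1`) gives 8 nM
Compound 2 (`Cc1ccc(-c2c(C)noc2CO)cc1S(=O)(=O)NC1CCCC1`) gives 6820 nM

Both numbers come from a functional assay on MT4 cells (Homo sapiens) for cytotoxicity, read by CellTiter-Glo, with a stated time of 5 days; a higher number here means that more compound is needed for the effect, a lower number that less compound is needed. Compound 2 stands highest of the two, and its gap to compound 1 lies far beyond the usual scatter. Compound 3 (`Cc1ccc(-c2cnoc2)cc1S(=O)(=O)NC1CCCC1`) differs from compound 2 in one place, on an aromatic carbon: a group of 5 heavy atoms (3 carbon, 1 nitrogen, 1 oxygen; one five-membered aromatic ring with 2 hetero atoms) in place of a group of 8 heavy atoms (5 carbon, 1 nitrogen, 2 oxygen; one five-membered aromatic ring with 2 hetero atoms), on an aromatic carbon. Within the data shown here, no measured pair shows this change, so the expectation is loose. A slight rise, not beyond the scatter, is expected, with a 1.8-fold higher number from compound 2 to compound 3 (0.25 log units; within the scatter) as the estimated step. For compound 3 the estimated value is 12000 nM, with 3000 nM to 50000 nM as the expected range.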

Compound 3, half-maximal effective concentration: 43200 nM
The estimate for compound 3 lay 3.6-fold (0.56 log units) below the measured number; measured number inside the range.
By their numbers in this assay, from the lowest: compound 1; then compound 2; then compound 3.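

In this assay there is a 6.3-fold higher number from compound 2 to compound 3 (0.80 log units; beyond the scatter) when the plain 1,2-oxazol-4-yl group replaces the larger group on the aromatic carbon, so the number responds to what sits at this position. Among these compounds, this is only one pair, and the change removes several atoms at once, so it cannot show which of them matters. Nothing available here explains the shift. Going by these compounds, it stays open how much of the step belongs to each atom removed. A single methyl group on the five-membered ring, or an amine in its place, might also read differently.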